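Working notes: amine swap on the shared core

This account rests on a few compounds, and the source may have more. Where it says the series, first, only, none or still open, it means among the compounds named here.

Compound 1 `CCCCN(CCCC)CN1C(=O)/C(=N\c2ncc(Cc3cc(OC)c(OC)c(OC)c3)c(N)n2)c2cc(Cl)ccc21` stands on no number at all: in an ADME assay on CCRF-CEM cells (Homo sapiens) for cytotoxicity, read by MTT assay, with a stated time of 5 days (a higher number here means that more compound is tolerated, a lower number that less compound is tolerated), compound 1 gives "not determined" (no result reported). Among the compounds with values here, compound 2 `COc1cc(Cc2cnc(/N=C3\C(=O)N(CN4CCN(c5cc6c(cc5F)c(=O)c(C(=O)O)cn6C5CC5)CC4)c4ccc(Cl)cc43)nc2N)cc(OC)c1OC` is the only measured neighbour. In this assay compound 2 reaches only a limit, > 200 ug/mL. The single entry of the series in this assay is therefore a limit, namely (the limit of > 200 ug/mL in this assay, at which 1 of the 2 values shown sits). Compound 3 `COc1cc(Cc2cnc(/N=C3\C(=O)N(CN4CCN(c5ccccn5)CC4)c4ccc(Cl)cc43)nc2N)cc(OC)c1OC` carries 4-(pyridin-2-yl)piperazin-1-yl in place of dibutylamino on a saturated chain carbon bound to an amide-type nitrogen in a ring. Within the data shown here, no measured step exists that would size this change in this assay, so no direction beyond the scatter is claimed. Compound 3 is expected in this assay to give 200 ug/mL, within 80 ug/mL to 400 ug/mL, most likely again reported as a limit.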

Compound 3, half-maximal cytotoxic concentration: 29.4 ug/mL
Compound 3: the middle estimate sits 6.8-fold (0.83 log units) above what was measured; measured number below the stated range.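

No step can be read between compound 1 and compound 3 in this assay; compound 3 stands alone at 29.4 ug/mL. On these data alone, what replacing dibutylamino with 4-(pyridin-2-yl)piperazin-1-yl does to the tolerated concentration in this assay stays open.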